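A few compounds are considered here, and "the series" means these few. Any claim that something is new, unique, unknown or untested is made for them only; others in the source may bear on it.

Measured compounds
Compound 1 `O=C(O)c1ccn(Cc2cc(Br)ccc2OCc2ccccc2)n1`: 55 nM
Compound 2 `Cc1cn(Cc2cc(Br)ccc2OCc2ccccc2)nc1C(=O)O`: 1350 nM
Compound 3 `O=C(O)c1nn(Cc2cc(Br)ccc2OCc2ccccc2)cc1Br`: < 2000 nM

All three were tested in a functional assay on CHO-K1 cells for antagonist activity at prostaglandin E2 receptor EP1 subtype (Homo sapiens), read by FLIPR; a lower number here means a stronger inhibitor, a higher number a weaker inhibitor. Compound 1 stands as the lowest number in this assay. From compound 1 to compound 2 the change is methyl in place of hydrogen on an aromatic carbon, and the result is a 25-fold higher number from compound 1 to compound 2 (1.39 log units; beyond the scatter). For compound 3 this assay reports only a limit, < 2000 nM (the limit of < 2000 nM in this assay, at which 1 of the 3 values shown sits). Because of that limit the step from compound 1 to compound 3 is a step that the limit leaves unreadable from compound 1 to compound 3, and the step from compound 2 to compound 3 is a step that the limit leaves unreadable from compound 2 to compound 3; compound 3 therefore stands somewhere within the limit, not at a number.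

Compound 4 `O=C(O)c1nn(Cc2cc(Br)ccc2OCc2ccccc2)cc1CO` has not yet been measured. It differs from compound 3 by hydroxymethyl in place of bromo on an aromatic carbon. Going by the values given here, the only readable step at that same aromatic carbon is the one from compound 1 to compound 2, which was large and toward a higher number; the two steps into compound 3 give no size. Compound 4 is therefore expected to sit well above compound 1 in this assay, in the region of compound 2, with a fair chance that only a limit is reported. The estimate for compound 4 is 1200 nM, within 250 nM to 6000 nM, which means an expected step that the limit leaves unreadable from compound 3 to compound 4.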

Compound 4, inhibition constant: < 2000 nM
Compound 4 was reported as a limit; the forecaster's own chance of this, stated with the estimate: 40%; the middle value does not contradict the limit.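

In this assay compound 4 gives < 2000 nM, which is a limit and not a number, so its steps from compound 1, compound 2 and compound 3 cannot be read: the limit of < 2000 nM in this assay, at which 2 of the 4 values shown sit.

The compounds shown leave open where compound 3 and compound 4 actually stand, and so whether hydroxymethyl, bromo and methyl differ at that aromatic carbon.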